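A few compounds are considered here, and "the series" means these few. Any claim that something is new, unique, unknown or untested is made for them only; others in the source may bear on it.

Compound 1 `Cn1cc(NC(=O)c2ncn3ccc(N4CCC[C@@H](N)C4)nc23)c(C(F)F)n1` and compound 2 `Cn1cc(NC(=O)c2cnc3ccc(N4CCC[C@@H](N)C4)nn23)c(C(F)F)n1` both carry a 3-aminopiperidin-1-yl group, on different cores. In a functional assay on HT cells (Homo sapiens) for cytotoxicity, read by CCK-8 assay, with a stated time of 72 h (a lower number here means a stronger inhibitor, a higher number a weaker inhibitor), compound 1 gives > 50000 nM, which is a limit of the assay and not a number. In this assay, among the measured compounds shown here, compound 2 gives 41700 nM, the only actual number so far, and it marks a weak inhibitor.

Compound 3 `Cn1cc(NC(=O)c2cnc3ccc(N[C@@H]4CCCNC4)nn23)c(C(F)F)n1` keeps the core of compound 2 and makes one change: (piperidin-3-yl)amino in place of 3-aminopiperidin-1-yl on an aromatic carbon. Here (piperidin-3-yl)amino stands in place of 3-aminopiperidin-1-yl on an aromatic carbon. For the measured compounds named here, no measured pair shows what such a change does, so the expectation starts from compound 2 at 41700 nM. In this assay, the expected result is a 1.4-fold lower number from compound 2 to compound 3 (0.14 log units; within the scatter), a step that would probably stay within the usual scatter, if anything towards a slightly stronger inhibitor. For compound 3, the estimated value is 30000 nM, with an expected range of 10000 nM to 60000 nM.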

Compound 3, half-maximal inhibitory concentration: 40100 nM
The estimate for compound 3 lay 1.3-fold (0.13 log units) below the measured number; measured number inside the range.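

Among the compounds shown here, this is the first measured step at this position on the shared core. Exchanging 3-aminopiperidin-1-yl for (piperidin-3-yl)amino on this aromatic carbon keeps the same atoms but joins them differently and changes the number of hydrogen-bond donors, yet it gives a 1.0-fold lower number from compound 2 to compound 3 (0.02 log units; within the scatter) in this assay. The two compounds therefore cannot be told apart here, so this rearrangement of the amine-bearing ring does not shift the reading, and compound 1 cannot add to this comparison, since its core differs and its result is a limit and not a number: the limit of > 50000 nM in this assay, at which 1 of the 3 values shown sits.

As far as these compounds go, it remains open whether a different group at this aromatic carbon, such as an open-chain aminoethylamino group or a carboxylic acid, would move the reading. From the compounds shown here alone, the effect of placing (piperidin-3-yl)amino on the core of compound 1 also remains open.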